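Swapping 4-fluorophenyl for thiophen-2-yl at the assay's limit

The source may report more compounds than this note shows. Statements on the series, on what has been measured and on what is new or still open speak of the compounds shown alone.

Measured in a functional assay on HeLa cells (Homo sapiens) for cytotoxicity, read by MTT assay, with a stated time of 48 h; on this read-out higher numbers stand for an effect only at larger amounts of compound and lower numbers for an effect already at smaller amounts:
- Compound 1 `CS(=O)(=O)c1ccc(Cc2n[nH]c(=S)n2/N=C/c2cccnc2)cc1`: > 100000 nM (a limit)
- Compound 2 `CS(=O)(=O)c1ccc(Cc2n[nH]c(=S)n2/N=C/c2ccc(F)cc2)cc1`: 100000 nM

For the measured compounds named here, compound 2 gives the only actual number so far, 100000 nM. Compound 1 gives only a limit, > 100000 nM. Compound 3 `CS(=O)(=O)c1ccc(Cc2n[nH]c(=S)n2/N=C/c2cccs2)cc1` keeps the shared core and changes one group: thiophen-2-yl in place of 4-fluorophenyl on a carbon with a double bond to nitrogen. Thiophen-2-yl takes the place of 4-fluorophenyl on a carbon with a double bond to nitrogen.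

Going by the values given here, only one measured step bears on this change, also an exchange of one aromatic group for another. That step, a number no higher from compound 1 to compound 2 (the limit leaves the size open), has no readable size. With compound 2 at 100000 nM and that size open, no shift beyond the usual scatter is expected in this assay, in either direction. The expected step is a 1.1-fold lower number from compound 2 to compound 3 (0.05 log units; within the scatter). Compound 3 is estimated at 90000 nM, with an expected range from 35000 nM to 200000 nM. A reading that gives only a limit would not be surprising.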

Compound 3, half-maximal effective concentration: 100000 nM
Compound 3: the middle estimate sits 1.1-fold (0.05 log units) below what was measured, within the range that was stated.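

In this assay there is no change at the digits printed from compound 2 to compound 3 (within the scatter). For the compounds shown here, this is the first step at this place, on a carbon with a double bond to nitrogen, whose size can be read. Thiophen-2-yl and 4-fluorophenyl therefore give the same printed number here, although thiophen-2-yl has a five-membered aromatic ring with 1 hetero atom and 4-fluorophenyl a six-membered aromatic ring of carbon only. Compound 1 gives > 100000 nM, which is a limit. Beyond that, there is a number no higher from compound 1 to compound 3 (the limit leaves the size open), and steps of this kind cannot be read.

From the compounds shown here alone, whether an amine, a carboxylic acid or a longer chain at this place would bring the effect down to smaller amounts of compound stays open. Where the values shown lie also matters for reading any further change: the limit of > 100000 nM in this assay, at which 1 of the 3 values shown sits.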